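This account rests on a few compounds, and the source may have more. Where it says the series, first, only, none or still open, it means among the compounds named here.

The measured compounds, each in a functional assay on HT-29 cells (Homo sapiens) for cytotoxicity, read by sulforhodamine B assay; a lower number here means that less compound is tolerated, a higher number that more compound is tolerated:

Compound 1, `CC1=CC[C@@H]([C@@](C)(O)CCCC(C)(C)NC(=S)NN)CC1`, gives a limit rather than a number, > 100000 nM.
Compound 2, `CC1=CC[C@@H]([C@@](C)(O)CCCC(C)(C)NC(=S)N/N=C\c2ccc(C)cc2)CC1`, likewise gives only a limit, > 100000 nM.
Compound 3, `CC1=CC[C@@H]([C@@](C)(O)CCCC(C)(C)NC(=S)N/N=C\c2ccccc2[N+](=O)[O-])CC1`, gives 44400 nM.

Compound 3 thus stands as the only one of the three with a measured number in this assay; the other two sit at the limit of > 100000 nM in this assay, at which 2 of the 3 values shown sit. Of the two steps between measured neighbours, the first, a step that the two limits leave unreadable from compound 1 to compound 2, cannot be sized, while the second, an at least 2.2-fold lower number from compound 2 to compound 3 (0.35 log units; beyond the scatter), shows that exchanging the aryl group on the hydrazone carbon can move the read-out by at least a modest amount.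

Compound 4, `CC1=CC[C@@H]([C@@](C)(O)CCCC(C)(C)NC(=S)N/N=C\c2ccccc2Cl)CC1`, differs from compound 3 by chloro in place of nitro on an aromatic carbon. Going by the values given here, no measured pair in this set exchanges one ortho substituent for another on the same ring, so the only guidance is that the aryl group is not inert, as the step from compound 2 to compound 3 demonstrates. Compound 3 is expected to be the closest reference, and compound 4 is estimated at 60000 nM, with a range from 25000 nM to 150000 nM, which corresponds to an expected step of a 1.4-fold higher number from compound 3 to compound 4 (0.13 log units; within the scatter) in this assay.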

Compound 4, concentration lethal to 50% of the cells: > 100000 nM
Compound 4 was reported as a limit; the forecaster's own chance of this, stated with the estimate: 35%; middle value at least 1.6-fold (0.22 log units) from the limit.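

Chloro in place of nitro on the aromatic carbon gives an at least 2.2-fold higher number from compound 3 to compound 4 (0.35 log units; beyond the scatter), the first exchange shown between two groups at the same place on the ring. Compound 4 gives only a limit in this assay, > 100000 nM. The number measured for compound 3 therefore does not extend to 2-chlorophenyl, and among the compounds shown only 2-nitrophenyl gives a readable value, with the other three at one shared limit: the limit of > 100000 nM in this assay, at which 3 of the 4 values shown sit.

The steps from compound 1 and from compound 2 to compound 4 join two limits and cannot be read, so the three compounds cannot be placed in any order relative to one another. The compounds shown also leave open how an amine, a methoxy group or a nitrile would read on this aromatic carbon, and whether a nitro group elsewhere on the ring would give a measurable number as well.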